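A few compounds are considered here, and "the series" means these few. Any claim that something is new, unique, unknown or untested is made for them only; others in the source may bear on it.

Among the compounds with values here, in a functional assay on HeLa cells (Homo sapiens) for inhibition, read by MTT assay, with a stated time of 48 h (a lower number here means a stronger inhibitor, a higher number a weaker inhibitor), compound 1 (`CN(C)c1ccc(C(c2c[nH]c3ccc(Br)cc23)c2c[nH]c3ccc(Br)cc23)cc1`) gives 12800 nM and compound 2 (`Clc1ccc(C(c2c[nH]c3ccc(Br)cc23)c2c[nH]c3ccc(Br)cc23)cc1`) gives 4800 nM as the lower of the two numbers so far. Within the data shown here, the only measured step (a 2.7-fold lower number from compound 1 to compound 2 (0.43 log units; beyond the scatter)) is modest but beyond the scatter. The change to compound 3 (`CCCC(c1c[nH]c2ccc(Br)cc12)c1c[nH]c2ccc(Br)cc12`) is propyl in place of 4-chlorophenyl on a saturated chain carbon bound to two aromatic carbons. The measured step exchanged one group on an aromatic carbon, whereas here the whole 4-chlorophenyl leaves. Neither measured compound lacks an aromatic ring at that place, so the step bears only loosely. Among the measured compounds shown here, its size (a 2.7-fold lower number from compound 1 to compound 2 (0.43 log units; beyond the scatter)) is still the one guide to how far a change in this part of the structure moves the number in this assay for this series. A step no larger than that is expected, with a slight lean to a higher number and the direction not fixed by the data. The expected step is a 1.6-fold higher number from compound 2 to compound 3 (0.19 log units; within the scatter) and carries wide uncertainty. For compound 3 the estimated value is 7500 nM with an expected range of 2500 nM to 20000 nM on present data.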

Compound 3, half-maximal inhibitory concentration: 3900 nM
Estimate against measurement, compound 3: 1.9-fold (0.28 log units) above; low and high end bracket the measured number.
By their numbers in this assay, from the lowest: compounds 3 and 2 (each within the scatter of the next); then compound 1.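

In this assay, propyl in place of 4-chlorophenyl on a saturated chain carbon bound to two aromatic carbons gives a 1.2-fold lower number from compound 2 to compound 3 (0.09 log units; within the scatter), so among these compounds an aromatic ring at this place is not needed for a number in the range of compound 2, and a group of 3 heavy atoms with no ring serves as well as one of 7 heavy atoms. Propyl in place of 4-(dimethylamino)phenyl gives a 3.3-fold lower number from compound 1 to compound 3 (0.52 log units; beyond the scatter), which leaves compound 1 apart from the other two, while the two compounds without the dimethylamino group stay within the scatter of each other. No measurement is at hand that bears on what lies behind these steps.

The compounds shown leave open how a longer chain such as hexyl, or a saturated ring such as cyclohexyl, would read at this place, and so whether the number tracks chain length or ring content at all. Also open, on these data alone, is how a propyl chain carrying an amine or a carboxylic acid would read in this assay.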